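The source may hold more compounds than are shown below. What is called first, only, known or untested is meant among the compounds shown, and "the series" means these compounds.

Measured compounds:
compound 1 `C=CC(=O)Nc1cccc(-n2cnc3cnc(Nc4ccc(N5CCN(C(C)=O)C(C)C5)cc4)nc32)c1` — > 40000 nM
compound 2 `C=CC(=O)Nc1cccc(-n2cnc3cnc(Nc4ccc(N5CCN(S(C)(=O)=O)CC5)cc4OC)nc32)c1` — 38600 nM

In a functional assay on Ramos cells (Homo sapiens) for antiproliferative activity, read by CCK-8 assay, with a stated time of 48 h (a higher number here means a weaker inhibitor, a lower number a stronger inhibitor), compound 1 gives > 40000 nM, which is a limit of the assay and not a number. Where compound 1 stands is told by the limit of > 40000 nM in this assay, at which 1 of the 2 values shown sits, so only a range is known for it. Compound 2 gives 38600 nM in this assay, a number that lies near that same region. Compound 3 `C=CC(=O)Nc1cccc(-n2cnc3cnc(Nc4ccc(N5CCN(S(C)(=O)=O)C(C)C5)cc4)nc32)c1` is not yet measured. It differs from compound 1 in a single place: methylsulfonyl in place of acetyl on an amine nitrogen in a ring. Compound 2 carries a methylsulfonyl on an amine nitrogen in a ring and gives 38600 nM in this assay, so no step beyond the usual scatter is expected from this change. Compound 3 is expected to give about 45000 nM in this assay, with a range of 20000 nM to 100000 nM and a fair chance that only a limit is reported. The expected step is a step that the limit leaves unreadable from compound 1 to compound 3, no change beyond the scatter.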

Compound 3, half-maximal inhibitory concentration: > 40000 nM
Compound 3: no number, only a limit (the forecaster's own chance of this, stated with the estimate: 55%); the middle value does not contradict the limit.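

Compound 1 and compound 3 each give only a limit and not a number, so no step can be read for methylsulfonyl in place of acetyl. The compounds shown leave open whether this change alters antiproliferative activity, and how far past the limit either compound lies.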